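A few compounds are considered here, and "the series" means these few. Any claim that something is new, unique, unknown or untested is made for them only; others in the source may bear on it.

Compound 2 `O=S(=O)(Nc1ncccn1)c1ccc2c(c1)OCC[C@@H]2c1ccc(C(F)(F)F)cc1-c1ccc(F)nc1` carries a 6-fluoropyridin-3-yl group, and in an ADME assay on the whole organism (Rattus norvegicus, strain Sprague-Dawley), read by LC-MS, with a stated time of 24 h, at a dose of 10 mg/kg by the oral route (on this read-out lower numbers stand for lower exposure and higher numbers for higher exposure at the dose given), compound 2 gives 58900 ng.h/mL. Among the compounds with values here, this is the higher of the two numbers known so far: compound 1 `Cn1nccc1-c1cc(C(F)(F)F)ccc1[C@H]1CCc2cc(S(=O)(=O)Nc3ncccn3)ccc21`, built on a different core, gives 23000 ng.h/mL, a lower number that lies beyond the usual scatter. Compound 3 `Cn1nccc1-c1cc(C(F)(F)F)ccc1[C@H]1CCOc2cc(S(=O)(=O)Nc3ncccn3)ccc21` keeps the core of compound 2 and changes one group: 1-methyl-1H-pyrazol-5-yl in place of 6-fluoropyridin-3-yl on an aromatic carbon. Within the data shown here, no measured pair isolates this change on a shared core, so the only hint comes from compound 1, which carries the same 1-methyl-1H-pyrazol-5-yl group on another core and gives 23000 ng.h/mL. A moderate fall in exposure is expected, estimated as a 1.7-fold lower number from compound 2 to compound 3 (0.23 log units; within the scatter). Compound 3 is therefore expected to give about 35000 ng.h/mL, with a likely range from 15000 ng.h/mL to 80000 ng.h/mL.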

Compound 3, area under the concentration-time curve: 58800 ng.h/mL
Compound 3: middle estimate off by 1.7-fold (0.23 log units), on the low side; the measured number falls inside the stated range.
By their numbers in this assay, from the lowest: compound 1; then compounds 3 and 2 (each within the scatter of the next).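

The step from the 6-fluoropyridin-3-yl group to the 1-methyl-1H-pyrazol-5-yl group on the shared core is a 1.0-fold lower number from compound 2 to compound 3 (0.00 log units; within the scatter) in this assay, so the two compounds cannot be told apart on this read-out. At this aromatic carbon, ortho to a large group and meta to a trifluoromethyl group, a six-membered and a five-membered aromatic ring therefore give matching exposure. Compound 3 shares its 1-methyl-1H-pyrazol-5-yl group with compound 1, which gives 23000 ng.h/mL, so that group alone does not set the lower number on the core of compound 1.

The compounds shown leave open how an amine, a carboxylic acid or a plain phenyl ring would behave at this position. Nothing shown here explains why the two rings match.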